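Swapping the amide substituent on a chromone acrylamide

The source may hold more compounds than are shown below. What is called first, only, known or untested is meant among the compounds shown, and "the series" means these compounds.

Measured compounds:
compound 1, `O=C(/C=C/c1coc2cc(O)ccc2c1=O)NCc1ccc(F)cc1`: > 100000 nM
compound 2, `COc1ccc2c(=O)c(/C=C/C(=O)NCc3cccc(F)c3)coc2c1`: 17600 nM

Two compounds share the same core and differ in their substituents. In a functional assay on HeLa cells (Homo sapiens) for inhibition, read by MTT assay, with a stated time of 48 h (on this read-out lower numbers stand for stronger inhibition and higher numbers for weaker inhibition), compound 1 gives only a limit of the assay, > 100000 nM, which is the limit (the limit of > 100000 nM in this assay, at which 1 of the 2 values shown sits). Among the compounds with values here, compound 2 is the only compound with an actual number in this assay, 17600 nM, so it is the sole fixed point for what follows.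

Compound 3, `COc1ccc2c(=O)c(/C=C/C(=O)Nc3ccc(Cl)cc3)coc2c1`, has not yet been measured in this assay. It differs from compound 2 as follows: 4-chlorophenyl in place of 3-fluorobenzyl on an amide-type nitrogen. Within the data shown here, no measured pair shows what such a change does here, so the direction of the step is not known from the data. The step from compound 2 to compound 3 is expected to be a 1.1-fold higher number from compound 2 to compound 3 (0.06 log units; within the scatter), that is, no step beyond the usual scatter. Compound 3 is therefore estimated at 20000 nM, with a range from 5000 nM to 80000 nM.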

Compound 3, half-maximal inhibitory concentration: > 100000 nM
Compound 3 gave a limit, no number; the forecaster's own chance of this, stated with the estimate: 25%; middle value at least 5.0-fold (0.69 log units) from the limit.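

On this shared core, the amide-type nitrogen is not a place where groups can be exchanged freely: in this assay, 4-chlorophenyl in place of 3-fluorobenzyl gives an at least 5.6-fold higher number from compound 2 to compound 3 (0.75 log units; beyond the scatter). Compound 3 gives > 100000 nM, which is a limit of the assay and not a number. The true size of the step therefore stays unknown and only its lower end can be read, because the value of compound 3 is such a limit: the limit of > 100000 nM in this assay, at which 2 of the 3 values shown sit.

The change replaces a benzyl with a phenyl and a fluorine with a chlorine in one step, so these compounds cannot show which of the two accounts for the weaker inhibition. A 4-chlorobenzyl or a 3-fluorophenyl group on the same nitrogen would separate the two changes.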